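The source may report more compounds than this note shows. Statements on the series, on what has been measured and on what is new or still open speak of the compounds shown alone.

Measured so far in a functional assay on HCT-116 cells (Homo sapiens) for antiproliferative activity, read by MTT assay, with a stated time of 72 h; a lower number here means a stronger inhibitor, a higher number a weaker inhibitor:

compound 1, `COc1ccc(/C=C2/CN(C)/C(=N/c3ccc(C)cc3)S2)cc1`: 11100 nM
compound 2, `COc1ccc(/C=C2\S/C(=N\c3ccc(C(C)(C)C)cc3)N(C)C2=O)cc1`: > 100000 nM
compound 3, `COc1ccc(/C=C2/CN(C)/C(=N/c3ccc(F)cc3)S2)cc1`: 10000 nM

Among the compounds with values here, compound 1 and compound 3 share one core and sit close together; the only measured step, a 1.1-fold lower number from compound 1 to compound 3 (0.05 log units; within the scatter), shows a change on the aromatic ring at that position that makes no difference beyond the scatter. Compound 2 stands apart: its value is a limit of the assay, not a number, and of the three values shown it is the one that sits at this limit (the limit of > 100000 nM in this assay, at which 1 of the 3 values shown sits).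

Compound 4, `COc1ccc(/C=C2\S/C(=N\c3ccc(Cl)cc3)N(C)C2=O)cc1`, keeps the core of compound 2 and differs from it only by chloro in place of tert-butyl on an aromatic carbon. Within the data shown here, no measured step on this core exists; the one step measured, on the other core, is within the scatter and swaps different groups, so it bears on the present change only as a sign that a small para substituent swap on this ring may matter little. Compound 4 is therefore expected to stay near compound 2, with a step of an at least 1.2-fold lower number from compound 2 to compound 4 (0.09 log units; that floor lies within the scatter) expected at most. The estimate for compound 4 in this assay is 80000 nM, expected to lie between 20000 nM and 300000 nM, with a fair chance that only a limit is reported again.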

Compound 4, half-maximal inhibitory concentration: 10400 nM
Beside the measured number, compound 4's estimate is 7.7-fold (0.89 log units) above it, and the stated range ends above it.
By their numbers in this assay, from the lowest: compounds 3, 4 and 1 (each within the scatter of the next). At a limit, above all of these: compound 2.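

In this assay, chloro in place of tert-butyl on an aromatic carbon gives an at least 9.6-fold lower number from compound 2 to compound 4 (0.98 log units; beyond the scatter) and so shows that this position on the core of compound 2 can move the read-out beyond the scatter. Within the data shown here, the one earlier step, a 1.1-fold lower number from compound 1 to compound 3 (0.05 log units; within the scatter) on the other core, put fluoro in place of methyl and gave no such sign. The new step is known only as a floor, and compound 2 is a limit of the assay, not a number: the limit of > 100000 nM in this assay, at which 1 of the 4 values shown sits.

Only tert-butyl and chloro are shown at this position on this core, so it stays open whether the step follows the loss of tert-butyl or the arrival of chloro. As far as these compounds go, how methyl, fluoro, an amine or a carboxylic acid would read in that place on the core of compound 2 also stays open.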